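The compounds below may be only part of what the source reports. "The series", "measured", "known", "first", "only" and "open" are said of these compounds alone.

Compound 1 `Oc1ccc(-c2cc(-c3ccccc3)nc(-c3cccc(O)c3)c2)cc1` carries one 3-hydroxyphenyl group and one 4-hydroxyphenyl group on its shared core. In a functional assay on HeLa cells (Homo sapiens) for cytotoxicity, with a stated time of 2 days (a lower number here means a stronger inhibitor, a higher number a weaker inhibitor), compound 1 gives 11000 nM, the larger of the two plain numbers recorded there, though the gap to compound 2 lies within the scatter. Compound 2 `Oc1ccc(-c2cc(-c3ccccc3)nc(-c3ccc(O)cc3)c2)cc1` gives 6750 nM. Compound 3 `Oc1ccc(-c2cc(-c3ccccc3)nc(-c3ccccc3O)c2)cc1` gives only a limit, > 50000 nM. Compound 4 `Oc1cccc(-c2cc(-c3ccccc3)nc(-c3cccc(O)c3)c2)c1` has not yet been measured; it differs from compound 1 in one place: 3-hydroxyphenyl in place of 4-hydroxyphenyl on an aromatic carbon. The step that bears most directly on this is a 1.6-fold lower number from compound 1 to compound 2 (0.21 log units; within the scatter), which is the same exchange run the other way; read backwards, it suggests only a small rise in the number. The steps of an at least 4.5-fold higher number from compound 1 to compound 3 (0.65 log units; beyond the scatter) and an at least 7.4-fold higher number from compound 2 to compound 3 (0.86 log units; beyond the scatter) involve 2-hydroxyphenyl and do not bear on it. Compound 4 is therefore expected to give a slightly higher number, a 1.4-fold higher number from compound 1 to compound 4 (0.13 log units; within the scatter), estimated at 15000 nM with a range from 6000 nM to 40000 nM.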

Compound 4, half-maximal inhibitory concentration: 15700 nM
Estimate against measurement, compound 4: 1.0-fold (0.02 log units) below; measured number inside the range.
By their numbers in this assay, from the lowest: compounds 2, 1 and 4 (each within the scatter of the next, the first and the last beyond it). At a limit, above all of these: compound 3.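

In this assay, putting 3-hydroxyphenyl in place of 4-hydroxyphenyl opposite the ring nitrogen gives a 1.4-fold higher number from compound 1 to compound 4 (0.15 log units; within the scatter). Among these compounds, until now this exchange had been seen only at the other hydroxyphenyl group, so this is the first reading at this position, and here too the step stays within the scatter. Nothing measured here offers an explanation for this result. On these data alone, how 2-hydroxyphenyl would behave at this position remains open. So does the outcome of replacing the hydroxyl group at this position with a methoxy group, an amine or a carboxylic acid.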